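The compounds below may be only part of what the source reports. "The series", "measured", "known", "first", "only" and "open" are said of these compounds alone.

Series notes, three esters measured in a functional assay on HCT-15 cells (Homo sapiens) for antiproliferative activity, read by sulforhodamine B assay, with a stated time of 48 h, tested at 50 uM (a lower number here means less inhibition, a higher number more inhibition at the concentration tested (going by the name of the read-out)), and one still open.

Compound 1 `CC1=CC[C@H](C(C)C)c2cc(C)c(OC(=O)c3ccc([N+](=O)[O-])cc3)cc21` gives 67.8% in this assay and is the lowest of the three numbers. Compound 3 `COc1ccc(C(=O)Oc2cc3c(C)ccc(C(C)C)c3cc2C)cc1` gives 84% in this assay, beyond the scatter above compound 1. Compound 2 `Cc1cc2c(C(C)C)ccc(C)c2cc1OC(=O)c1ccc([N+](=O)[O-])cc1` gives 97.6% in this assay, the highest of the three and beyond the scatter above both others. Within the data shown here, the single one-place step measured so far, a number 13.6 percentage points lower from compound 2 to compound 3 (beyond the scatter), concerns the group on the aromatic carbon of the benzoate and runs on a core different from that of compound 1.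

Compound 4 `CC1=CC[C@H](C(C)C)c2cc(C)c(OC(=O)c3cccc([N+](=O)[O-])c3)cc21` differs from compound 1 as follows: 3-nitrophenyl in place of 4-nitrophenyl on a carbonyl carbon. Among the measured compounds shown here, no measured pair shows what moving the nitro group within the ring does; the step from compound 2 to compound 3 exchanges the group rather than its position, so it bears only indirectly. With both compounds carrying the same atoms and the same core, a step in this assay is expected to stay within the scatter, in no set direction: a number 0.2 percentage points higher from compound 1 to compound 4 (within the scatter). Compound 4 is therefore estimated at 68% in this assay, with a range from 48% to 86%.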

Compound 4, a percentage reported as inhibition, at one concentration (the size of the read-out at that concentration, not a potency): 45.9%
The estimate for compound 4 lay 22.1 percentage points above the measured number; measured number below the stated range.
By their numbers in this assay, from the lowest: compound 4; then compound 1; then compound 3; then compound 2.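

On the core of compound 1, the position of the nitro group on the benzoate ring matters in this assay: 3-nitrophenyl in place of 4-nitrophenyl on a carbonyl carbon gives a number 21.9 percentage points lower from compound 1 to compound 4 (beyond the scatter), although the two compounds have the same atoms. Among these compounds, the earlier step, a number 13.6 percentage points lower from compound 2 to compound 3 (beyond the scatter), exchanged one group for another on a different core, so this is the first pair in which the group stays the same and only its place on the ring changes. Nothing at hand accounts for the drop in inhibition, and the pair records only its size and direction.

Whether moving the nitro group has a similar result on the core of compound 2 remains open, as the shown compounds leave that core with 4-nitrophenyl and a methoxy-bearing benzoate only. As far as these compounds go, it is also open whether the change follows the nitro group specifically or would appear with other groups on the ring, such as an amine or a carboxylic acid.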